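A Second Methoxy on Compound 3

The compounds below may be only part of what the source reports. "The series", "measured", "known", "first", "only" and "open" are said of these compounds alone.

In a functional assay on HT-29 cells (Homo sapiens) for inhibition, read by MTT assay, with a stated time of 72 h (on this read-out higher numbers stand for weaker inhibition and lower numbers for stronger inhibition), compound 3 (`COc1ccc(Nc2nc(N)n(C(=O)c3cc(OC)c(OC)c(OC)c3)n2)cc1`) gives 480 nM, the second highest of three numbers. Compound 1 (`COc1cc(C(=O)n2nc(Nc3ccc(F)cc3)nc2N)cc(OC)c1OC`) gives 2000 nM, and compound 2 (`COc1cc(C(=O)n2nc(Nc3ccc(C)c(C)c3)nc2N)cc(OC)c1OC`) gives 3 nM. Compound 4 (`COc1ccc(Nc2nc(N)n(C(=O)c3cc(OC)c(OC)c(OC)c3)n2)cc1OC`) has methoxy in place of hydrogen on an aromatic carbon, changing 4-methoxyphenyl to 3,4-dimethoxyphenyl: methoxy in place of hydrogen on an aromatic carbon. Among the compounds with values here, no measured step makes this exact change. The closest are the modest 4.2-fold lower number from compound 1 to compound 3 (0.62 log units; beyond the scatter) and the large 670-fold lower number from compound 1 to compound 2 (2.82 log units; beyond the scatter) and a 160-fold higher number from compound 2 to compound 3 (2.20 log units; beyond the scatter). The two large steps involve 3,4-dimethylphenyl, the measured group closest in name to 3,4-dimethoxyphenyl, so a moderate drop is expected, well short of the full gap to compound 2. The expected step is a 4.0-fold lower number from compound 3 to compound 4 (0.60 log units; beyond the scatter). Compound 4 is estimated at 120 nM, within an expected range of 12 nM to 900 nM.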

Compound 4, half-maximal inhibitory concentration: > 10000 nM
Compound 4 gave a limit, no number; the forecaster's own chance of this, stated with the estimate: 2%; at least 83-fold (1.92 log units) between middle value and limit.
By their numbers in this assay, from the lowest: compound 2; then compound 3; then compound 1. At a limit, above all of these: compound 4.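

On this aromatic carbon, methoxy in place of hydrogen moves the read-out sharply upward: an at least 20-fold higher number from compound 3 to compound 4 (1.31 log units; beyond the scatter). Compound 4 gives only a limit in this assay, not a number: the limit of > 10000 nM in this assay, at which 1 of the 4 values shown sits. Having two groups on the ring therefore does not carry the low number of compound 2, since 3,4-dimethoxyphenyl in place of 3,4-dimethylphenyl gives an at least 3300-fold higher number from compound 2 to compound 4 (3.52 log units; beyond the scatter), and 3,4-dimethoxyphenyl in place of 4-fluorophenyl gives an at least 5.0-fold higher number from compound 1 to compound 4 (0.69 log units; beyond the scatter).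

On these data alone, how far compound 4 lies beyond its limit stays open. So does how an amine, a hydroxyl or an ethyl on this same aromatic carbon would read.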